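This account rests on a few compounds, and the source may have more. Where it says the series, first, only, none or still open, it means among the compounds named here.

Working notes on the series. All four compounds share one core and differ only in the group on the aromatic carbon that sits ortho to a large group. In a functional assay for antagonist activity at Alpha-1A adrenergic receptor (Oryctolagus cuniculus) (on this read-out lower numbers stand for tighter binding and higher numbers for weaker binding), compound 1 `CN(C)C(=O)c1cccnc1NCCCN1CCN(c2ccccc2OC(F)(F)F)CC1` gives 3.16 nM; compound 2 `CN(C)C(=O)c1cccnc1NCCCN1CCN(c2ccccc2-c2ccccc2)CC1` gives 1.26 nM; compound 3 `CN(C)C(=O)c1cccnc1NCCCN1CCN(c2ccccc2-c2ncco2)CC1` gives 0.316 nM. Compound 3 holds the lowest of the three numbers: a 10-fold lower number from compound 1 to compound 3 (1.00 log units; beyond the scatter) and a 4.0-fold lower number from compound 2 to compound 3 (0.60 log units; beyond the scatter), both beyond the scatter, while a 2.5-fold lower number from compound 1 to compound 2 (0.40 log units; beyond the scatter) separates the other two. Compound 4 `CCCc1ccccc1N1CCN(CCCNc2ncccc2C(=O)N(C)C)CC1` has not yet been measured. The change is propyl in place of 1,3-oxazol-2-yl on an aromatic carbon. Within the data shown here, no measured step brings propyl in, so none bears on it directly; what the three steps show is that exchanging this one group has moved the number by amounts between a 2.5-fold lower number from compound 1 to compound 2 (0.40 log units; beyond the scatter) and a 10-fold lower number from compound 1 to compound 3 (1.00 log units; beyond the scatter), and that compound 3 carries the lowest number seen. A rise in the number is therefore expected, estimated at a 5.1-fold higher number from compound 3 to compound 4 (0.70 log units; beyond the scatter). Compound 4 is expected to give about 1.6 nM, with a range of 0.5 nM to 5 nM.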

Compound 4, dissociation constant: 0.2 nM
The estimate for compound 4 lay 8.0-fold (0.90 log units) above the measured number, outside the stated range (below it).
By their numbers in this assay, from the lowest: compounds 4 and 3 (each within the scatter of the next); then compound 2; then compound 1.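

In this assay, propyl in place of 1,3-oxazol-2-yl gives a 1.6-fold lower number from compound 3 to compound 4 (0.20 log units; within the scatter), so a group with no ring and no hydrogen-bond acceptors on this aromatic carbon cannot be told apart from the best group seen before. Propyl also gives a 6.3-fold lower number from compound 2 to compound 4 (0.80 log units; beyond the scatter) and a 16-fold lower number from compound 1 to compound 4 (1.20 log units; beyond the scatter), so neither a ring nor an acceptor is needed for a low number at this position in these compounds. No supporting measurement accounts for these steps.

Propyl is the only open chain among the compounds shown, so it remains open whether ethyl, butyl or a longer chain would keep the number at this level. On these data alone, it is also open how an amine or a carboxylic acid on this aromatic carbon would compare.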